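The source may hold more compounds than are shown below. What is called first, only, known or untested is meant among the compounds shown, and "the series" means these compounds.

In a functional assay on NCI-H460 cells (Homo sapiens) for inhibition, read by CCK-8 assay, with a stated time of 72 h, tested at 1 uM (a lower number here means less inhibition of growth, a higher number more inhibition of growth at the concentration tested), compound 1 `CN(C)C(=O)c1cc2cnc(Nc3ccc(NC(=O)C4(C(=O)Nc5ccc(F)cc5)CC4)cc3)nc2n1C1CCCC1`, which carries 4-fluorophenyl on an amide-type nitrogen, gives 79.9%. Compound 2 `CN(C)C(=O)c1cc2cnc(Nc3ccc(NC(=O)C4(C(=O)Nc5ccc(Cl)cc5)CC4)cc3)nc2n1C1CCCC1`, with 4-chlorophenyl there, gives 21.3%, and compound 3 `CN(C)C(=O)c1cc2cnc(Nc3ccc(NC(=O)C4(C(=O)Nc5ccccc5F)CC4)cc3)nc2n1C1CCCC1`, with 2-fluorophenyl, gives 28.2%. Two measured steps place compound 3 among these values. One is a number 51.7 percentage points lower from compound 1 to compound 3 (beyond the scatter), and the other is a number 6.9 percentage points higher from compound 2 to compound 3 (within the scatter). It therefore lies far short of the top value and level with the 4-chlorophenyl compound.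

Compound 4 `CN(C)C(=O)c1cc2cnc(Nc3ccc(NC(=O)C4(C(=O)Nc5ccc(Cl)c(C(F)(F)F)c5)CC4)cc3)nc2n1C1CCCC1` has 4-chloro-3-(trifluoromethyl)phenyl in place of 2-fluorophenyl on an amide-type nitrogen. The nearest guide is the measured step of a number 58.6 percentage points lower from compound 1 to compound 2 (beyond the scatter), chloro in place of fluoro on an aromatic carbon. Both large steps lead away from 4-fluorophenyl, a group that compound 4 also lacks. Like compound 2, at 21.3%, compound 4 carries a chloro group. Among the measured compounds shown here, no tested compound carries trifluoromethyl, so that part of the change is unexplored and the range has to stay wide. Only a small move in this assay is therefore expected, and the estimated step is a number 1.8 percentage points higher from compound 3 to compound 4 (within the scatter). For compound 4 the expected value is 30%, with an estimated range of 8% to 65%.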

Compound 4, percent growth inhibition at one concentration: 2.1%
Beside the measured number, compound 4's estimate is 27.9 percentage points above it; measured number below the stated range.
By their numbers in this assay, from the lowest: compound 4; then compounds 2 and 3 (each within the scatter of the next); then compound 1.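

In this assay, among the compounds shown here, adding trifluoromethyl to the 4-chlorophenyl group on the amide-type nitrogen gives a number 19.2 percentage points lower from compound 2 to compound 4 (beyond the scatter), so a ring that already scored low can lose still more growth inhibition, which the earlier compounds could not show. For the compounds shown here, the full replacement gives a number 26.1 percentage points lower from compound 3 to compound 4 (beyond the scatter) against the 2-fluorophenyl group and a number 77.8 percentage points lower from compound 1 to compound 4 (beyond the scatter) against the 4-fluorophenyl group, which makes compound 4 the lowest of the four and shows that this larger substituted ring sits furthest from the best value so far. Nothing available here explains why the added trifluoromethyl lowers the number.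

The compounds shown leave open whether trifluoromethyl would cost as much on the 4-fluorophenyl ring, the only ring here that gives a high number, or whether that ring's advantage would survive the addition. They also leave open whether a methoxy group or an amine in place of the halogen on this ring would keep growth inhibition high or lose it as chloro does.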